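Amide variation on a sulfonamide-bearing core: cytotoxicity estimate

The source may hold more compounds than are shown below. What is called first, only, known or untested is meant among the compounds shown, and "the series" means these compounds.

Measured compounds:
Compound 1, `CC(Cl)CC(=O)NC1=C(C#N)C(c2ccc(Cl)cc2Cl)C2=C(CCCC2=O)N1c1ccc(S(N)(=O)=O)cc1`: 55%
Compound 2, `N#CC1=C(NC(=O)C2CC2)N(c2ccc(S(N)(=O)=O)cc2)C2=C(C(=O)CCC2)C1c1ccc(Cl)cc1Cl`: 40%
Compound 3, `Cc1ccc(C(=O)NC2=C(C#N)C(c3ccc(Cl)cc3Cl)C3=C(CCCC3=O)N2c2ccc(S(N)(=O)=O)cc2)cc1`: 40%

Three compounds sharing one core and differing only in the group on the amide carbonyl carbon were tested in a functional assay on Ehrlich cells (Mus musculus) for cytotoxicity, read by trypan blue exclusion, with a stated time of 2 h, tested at 50 ug/mL; on this read-out higher numbers stand for a stronger effect at the one concentration tested and lower numbers for a weaker effect. Compound 1 carries a 2-chloropropyl there and gives 55%. Compound 2 carries a cyclopropyl and gives 40%; compound 3 carries a 4-methylphenyl and gives 40%. Thus compound 3 stands level with compound 2 at the digits shown, the two together forming the lowest pair of the three, while a number 15 percentage points lower from compound 1 to compound 3 (beyond the scatter) and a number 15 percentage points lower from compound 1 to compound 2 (beyond the scatter). Between the two lowest, no change at the digits printed from compound 2 to compound 3 (within the scatter).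

Compound 4, `N#CC1=C(NC(=O)c2ccc([N+](=O)[O-])cc2)N(c2ccc(S(N)(=O)=O)cc2)C2=C(C(=O)CCC2)C1c1ccc(Cl)cc1Cl`, keeps the 4-methylphenyl framework of compound 3 but swaps one substituent: nitro in place of methyl on an aromatic carbon. Among the measured compounds shown here, no measured step exchanges one substituent on an aryl amide, so the only guidance is indirect: replacing the whole amide group gave modest movements at most, and the cyclopropyl-to-aryl exchange gave none beyond the scatter. On that basis a step of a number 2 percentage points higher from compound 3 to compound 4 (within the scatter) is expected, essentially none beyond the scatter, with compound 4 estimated at 42% in this assay, within a range of 25% to 60%.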

Compound 4, a percentage reported as activity, at one concentration (the size of the read-out at that concentration, not a potency): 50%
Compound 4: middle estimate off by 8 percentage points, on the low side; low and high end bracket the measured number.
By their numbers in this assay, from the lowest: compounds 2, 3, 4 and 1 (each within the scatter of the next, the first and the last beyond it).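

In this assay, the exchange of nitro for methyl on an aromatic carbon of the aryl amide gives a number 10 percentage points higher from compound 3 to compound 4 (within the scatter) and so is the first change shown that leaves the amide group itself in place and alters only a substituent on it. Compound 4 also shows a number 10 percentage points higher from compound 2 to compound 4 (within the scatter) and a number 5 percentage points lower from compound 1 to compound 4 (within the scatter) as its steps to the other two compounds, so it is the only one of the cyclopropyl and aryl amides not set apart from the 2-chloropropyl amide of compound 1, and the separation seen for compounds 2 and 3 therefore does not extend to every non-chloropropyl group at this position. Nothing available bears on why the numbers at this position fall as they do.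

On these data alone, whether an amine or a carboxylic acid in place of the nitro on that aromatic carbon, or a longer chain in place of the 2-chloropropyl on the carbonyl carbon, would read apart from these four compounds stays open. Each compound is also known only at the one concentration, so the numbers leave their potency order open.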